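This account rests on a few compounds, and the source may have more. Where it says the series, first, only, none or still open, it means among the compounds named here.

Within the data shown here, in a physicochemical assay for pharmacokinetics, at pH 4, tested at 100 ug/mL (on this read-out lower numbers stand for a shorter-lived compound and higher numbers for a longer-lived compound), compound 1 `N[C@@H](CSNC(=O)[C@@H](CCC(F)(F)F)N(Cc1ccc(-c2ncon2)cc1F)S(=O)(=O)c1ccc(Cl)cc1)C(=O)O` gives 418 h, the only exact number so far. Compound 2 `O=C(NSc1ccccc1)[C@@H](CCC(F)(F)F)N(Cc1ccc(-c2ncon2)cc1F)S(=O)(=O)c1ccc(Cl)cc1` gives > 500 h, which is a limit and not a number. Among the measured compounds shown here, the one measured step is an at least 1.1-fold higher number from compound 1 to compound 2 (0.07 log units; that floor lies within the scatter). For the measured compounds named here, it swaps the whole group on the sulfur, so it shows only that a large change there left no step beyond the scatter.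

Compound 3 `CCOC(=O)[C@@H](N)CSNC(=O)[C@@H](CCC(F)(F)F)N(Cc1ccc(-c2ncon2)cc1F)S(=O)(=O)c1ccc(Cl)cc1` makes a smaller change to compound 1, turning carboxy into ethoxycarbonyl, with ethyl in place of hydrogen on an oxygen next to a carbonyl group. Going by the values given here, no measured step tests this change directly, so no shift beyond the scatter is expected in this assay. The expected step is a 1.0-fold higher number from compound 1 to compound 3 (0.00 log units; within the scatter). Compound 3 is expected to give about 420 h, with an estimated range of 210 h to 840 h. A reading at the limit of > 500 h in this assay, at which 1 of the 2 values shown sits, also remains possible.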

Compound 3, half-life: 258 h
The estimate for compound 3 lay 1.6-fold (0.21 log units) above the measured number; the range from low to high includes it.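

Turning carboxy into ethoxycarbonyl gives the first direct reading of a small change at this place in this assay: the step is a 1.6-fold lower number from compound 1 to compound 3 (0.21 log units; within the scatter), so ethyl in place of hydrogen on this oxygen next to a carbonyl group moves the number no further than the scatter. Set against the phenyl group on the sulfur, the step is an at least 1.9-fold lower number from compound 2 to compound 3 (0.28 log units; that floor lies within the scatter), so this pair also shows no step beyond the scatter, though the true gap could be larger. The reading for compound 2 is a limit and not a number: the limit of > 500 h in this assay, at which 1 of the 3 values shown sits.

The compounds shown leave open whether a longer chain such as butyl or a ring-bearing group such as benzyl in place of ethyl would give a step beyond the scatter. They also leave open what an acetamido group would do in place of the amino group of amino(ethoxycarbonyl)methyl.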